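A few compounds are considered here, and "the series" means these few. Any claim that something is new, unique, unknown or untested is made for them only; others in the source may bear on it.

Among the measured compounds shown here, compound 2 `Cc1ccc2c(NCc3ccc(NC(=O)C4CCN(CC5CCNCC5)CC4)cc3)nc(N(C)C)nc2c1` is one of two compounds measured in a functional assay on SV5A8 cells (Homo sapiens) for cytotoxicity; on this read-out lower numbers stand for stronger inhibition and higher numbers for weaker inhibition. For compound 2, this assay reports only a limit, > 8070 nM, rather than a number. Compound 1 `Cc1ccc2c(NCc3ccc(NC(=O)C4CCN(Cc5ccccc5)CC4)cc3)nc(N3CCN[C@@H](C)C3)nc2c1` likewise gives only a limit in this assay, > 8860 nM. Both values on hand are thus limits, and compound 2 is not set apart from compound 1 by them. Compound 3 `Cc1ccc2c(NCc3ccc(NC(=O)C4CCN(Cc5ccc(F)cc5)CC4)cc3)nc(N(C)C)nc2c1` differs from compound 2 by 4-fluorophenyl in place of piperidin-4-yl on a saturated chain carbon bound to an amine nitrogen in a ring. For the measured compounds named here, with no measured step to lean on, the step from compound 2 to compound 3 is expected to be none beyond the usual scatter, a step that the limit leaves unreadable from compound 2 to compound 3. Compound 3 is therefore estimated at 9000 nM in this assay, between 3000 nM and 30000 nM, most probably again reported as a limit.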

Compound 3, half-maximal inhibitory concentration: > 4820 nM
Compound 3: only a limit was reported; the forecaster's own chance of this, stated with the estimate: 70%; the middle value lies beyond the limit too.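

Compound 2 and compound 3 are both reported only as limits in this assay, so no step can be read between them. As far as these compounds go, whether swapping piperidin-4-yl for 4-fluorophenyl changes the read-out at all stays open.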